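The source may report more compounds than this note shows. Statements on the series, on what has been measured and on what is new or still open speak of the compounds shown alone.

Measured so far:
compound 1 `CC(C)CCOC(=O)OCC(CO)CCn1cnc2cnc(N)nc21` – 357000 nM
compound 2 `CC(C)OC(=O)OCC(CO)CCn1cnc2cnc(N)nc21` – > 500000 nM

Among the measured compounds shown here, in a functional assay on Vero cells (Chlorocebus sabaeus) for cytotoxicity (on this read-out higher numbers stand for lower toxicity in this test and lower numbers for higher toxicity in this test), compound 1 gives 357000 nM, the only plain number among the values shown. For compound 2 the read-out is a limit of the assay, > 500000 nM. The measured step is thus only a floor: an at least 1.4-fold higher number from compound 1 to compound 2 (0.14 log units; that floor lies within the scatter), and it runs into (the limit of > 500000 nM in this assay, at which 1 of the 2 values shown sits). Compound 3 `COC(=O)OCC(CO)CCn1cnc2cnc(N)nc21` carries the same kind of change, taken further: hydrogen in place of isobutyl on a saturated chain carbon bound to an oxygen next to a carbonyl group. Shortening the ester chain gave no shift beyond the scatter, so for compound 3 no step beyond the scatter is expected in this assay, at most a modest move toward a higher number. Compound 3 is estimated at 450000 nM, between 220000 nM and 1000000 nM, a step of a 1.3-fold higher number from compound 1 to compound 3 (0.10 log units; within the scatter) that is expected to stay within the scatter.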

Compound 3, half-maximal cytotoxic concentration: > 500000 nM
Compound 3 ended at the assay's limit; the forecaster's own chance of this, stated with the estimate: 45%; middle value at least 1.1-fold (0.04 log units) away from the limit.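

The step from isopentyloxycarbonyl to methoxycarbonyl reads an at least 1.4-fold higher number from compound 1 to compound 3 (0.14 log units; that floor lies within the scatter). Even the shortest chain shown at this position therefore gives only a floor in this assay, so a second shortening of the chain also yields no step shown to lie beyond the scatter. The step between compound 2 and compound 3 cannot be read, as both values are limits, and the series now gathers there: the limit of > 500000 nM in this assay, at which 2 of the 3 values shown sit.

From the compounds shown here alone, how far compound 2 and compound 3 lie past that limit stays open. Also open, going by these compounds, is whether a longer chain such as octyl, or an amine on the chain, would give a plain number in this assay.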